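Opening notes on the amide series in the tail flick test

The compounds below may be only part of what the source reports. "The series", "measured", "known", "first", "only" and "open" are said of these compounds alone.

Measured so far:
compound 1 `CC(C)C[C@H](NC(=O)CN(c1nc(Cl)nc2[nH]cnc12)C1CC1)C(=O)OCc1ccccc1`, 15.2%
compound 2 `NC(=O)CC[C@H](NC(=O)CN(c1nc(Cl)nc2[nH]cnc12)C1CC1)C(=O)O`, 41.1%
compound 3 `NC(=O)CC[C@H](NC(=O)CN(c1nc(Cl)nc2[nH]cnc12)C1CC1)C(=O)OCc1ccccc1`, 42.8%

In a functional assay on the whole organism (Tail, strain ICR) with Mus musculus as the target, in the tail flick test, with a stated time of 90 min, at a dose of 25 umol/kg by the oral route (a higher number here means a stronger effect of the compound at the dose given, a lower number a weaker effect), compound 2 gives 41.1%, the second highest of the three numbers; compound 3 sits within the scatter of it, while compound 1 lies well below. The step from compound 2 to compound 4 `O=C(O)CNC(=O)CN(c1nc(Cl)nc2[nH]cnc12)C1CC1` reads (hydrogen in place of 2-carbamoylethyl on a saturated chain carbon bound to an amide-type nitrogen and a carbonyl carbon). Among the compounds with values here, two measured steps bear on this. The change at the ester oxygen, a number 1.7 percentage points higher from compound 2 to compound 3 (within the scatter), shows that the acid and the benzyl ester of the same side chain give the same read-out, so the change from the acid form of compound 2 is not by itself a concern. The change on the side chain, a number 27.6 percentage points higher from compound 1 to compound 3 (beyond the scatter), shows that what sits on that carbon shifts the read-out by a modest but clear amount. Since compound 4 carries no side chain there at all, a drop beyond the scatter in this assay is expected, roughly of the size seen between compound 1 and compound 3, hence a number 21.1 percentage points lower from compound 2 to compound 4 (beyond the scatter). Compound 4 is therefore estimated at 20%, with a range from 5% to 38%.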

Compound 4, a percentage reported as activity, at one dose (the size of the read-out at that dose, not a potency): 32.3%
Compound 4: middle estimate off by 12.3 percentage points, on the low side, and the stated range covers the measured number.
By their numbers in this assay, from the lowest: compound 1; then compounds 4, 2 and 3 (each within the scatter of the next, the first and the last beyond it).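

Hydrogen in place of 2-carbamoylethyl on a saturated chain carbon bound to an amide-type nitrogen and a carbonyl carbon gives a number 8.8 percentage points lower from compound 2 to compound 4 (within the scatter) in this assay, so at this one dose the read-out of the free acid series does not depend on that side chain. The earlier step, a number 27.6 percentage points higher from compound 1 to compound 3 (beyond the scatter), therefore cannot be read as a gain supplied by a side chain at this position as such, and the group on this carbon matters in the comparison of side chains but not in this comparison with hydrogen. No measurement at hand explains this result.

Open, on these data alone, is how a methyl group, a carboxylic acid side chain or a longer chain ending in an amine would read on this carbon. Also open, as far as these compounds go, is how the benzyl ester of compound 4 would read.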